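Chloro to isopropoxy on the free-hydroxyl core

The source may hold more compounds than are shown below. What is called first, only, known or untested is meant among the compounds shown, and "the series" means these compounds.

Of the compounds shown here, two have been measured in an ADME assay on DU-145 cells (Homo sapiens) for cytotoxicity, read by MTT assay, with a stated time of 72 h; a higher number here means a weaker inhibitor, a lower number a stronger inhibitor. Compound 1 `COc1ccc(C2=C(c3cc(OC)c(OC)c(OC)c3)C(=O)C(O[SiH2]C(C)(C)C)C2)cc1OC(C)C` gives 6.3 ug/mL. Compound 2 `COc1ccc(C2=C(c3cc(OC)c(OC)c(OC)c3)C(=O)C(O)C2)cc1Cl` gives 40 ug/mL, the highest of the two numbers, with compound 1 giving a lower number, beyond the scatter. Compound 3 `COc1ccc(C2=C(c3cc(OC)c(OC)c(OC)c3)C(=O)C(O)C2)cc1OC(C)C` carries the change (isopropoxy in place of chloro on an aromatic carbon), set on an aromatic carbon of a six-membered aromatic ring of carbon only, ortho to a methoxy group. Going by the values given here, no measured pair isolates this change. Compound 3 is expected to give a lower number than compound 2, a step of a 2.7-fold lower number from compound 2 to compound 3 (0.43 log units; beyond the scatter), because compound 1, which also carries isopropoxy, gives 6.3 ug/mL. The estimate for compound 3 is 15 ug/mL, with a range from 5 ug/mL to 45 ug/mL.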

Compound 3, half-maximal inhibitory concentration: > 100 ug/mL
Compound 3: only a limit was reported; the forecaster's own chance of this, stated with the estimate: 5%; at least 6.6-fold (0.82 log units) between middle value and limit.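

Compound 3 sits at a limit of this assay, not at a number: the limit of > 100 ug/mL in this assay, at which 1 of the 3 values shown sits. On the free-hydroxyl core, isopropoxy in place of chloro on this aromatic carbon goes the other way from the lower number expected, with an at least 2.5-fold higher number from compound 2 to compound 3 (0.39 log units; beyond the scatter) as a step bounded only from one side. A hydrogen atom in place of the silicon-bearing group on oxygen gives an at least 15-fold higher number from compound 1 to compound 3 (1.20 log units; beyond the scatter), so isopropoxy alone does not carry the lower number.

Still open, from the compounds shown here alone, is how far compound 3 lies past its limit. Also open, going by these compounds, is how an amine or a longer ether chain on this aromatic carbon would read.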